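A few compounds are considered here, and "the series" means these few. Any claim that something is new, unique, unknown or untested is made for them only; others in the source may bear on it.

Among the measured compounds shown here, in an ADME assay on microsomes from liver (Mus musculus) for pharmacokinetics, read by LC-MS, using NADPH, with stated times of 5 min, 15 min and 30 min, tested at 10 uM (on this read-out higher numbers stand for fast clearance and lower numbers for slow clearance), three compounds have numbers so far. Compound 1 (`CCC(=O)N[C@@H](C)c1ccc(NC(=O)N2CC(c3ccc(N)nc3)C2)cc1`) gives 22 mL.min-1.g-1, compound 2 (`C[C@H](NC(=O)c1ncccn1)c1ccc(NC(=O)N2CC(c3cncc(N)c3)C2)cc1`) gives 83.4 mL.min-1.g-1, and compound 3 (`C[C@H](NC(=O)C1CCOCC1)c1ccc(NC(=O)N2CC(c3cncc(N)c3)C2)cc1`) gives 60.2 mL.min-1.g-1. Compound 3 thus stands within the scatter of compound 2, while the number of compound 1 lies lower than that of compound 3 by more than the scatter.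

The next structure, compound 4 (`CCC(=O)N[C@@H](C)c1ccc(NC(=O)N2CC(c3cncc(N)c3)C2)cc1`), differs from compound 3 in one place: ethyl in place of oxan-4-yl on a carbonyl carbon.

For the measured compounds named here, only one measured step concerns a change at this carbonyl carbon: a 1.4-fold lower number from compound 2 to compound 3 (0.14 log units; within the scatter). That step replaced pyrimidin-2-yl with oxan-4-yl and stayed within the scatter, though it says nothing about ethyl itself. Going by the values given here, compound 1 also carries the propanoyl group, and its value of 22 mL.min-1.g-1 points to a lower number, but no single-change step links it to compound 3, so it counts only modestly. A small move to a lower number, no larger than the scatter, is therefore expected in this assay. The expected step is a 1.5-fold lower number from compound 3 to compound 4 (0.18 log units; within the scatter). Compound 4 is estimated at 40 mL.min-1.g-1, with an expected range of 20 mL.min-1.g-1 to 75 mL.min-1.g-1.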

Compound 4, intrinsic clearance in microsomes: 56.9 mL.min-1.g-1
Compound 4: the middle estimate sits 1.4-fold (0.15 log units) below what was measured; the measured number falls inside the stated range.
By their numbers in this assay, from the lowest: compound 1; then compounds 4, 3 and 2 (each within the scatter of the next).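

In this assay the carbonyl carbon has now carried ethyl, oxan-4-yl and pyrimidin-2-yl, and both a 1.1-fold lower number from compound 3 to compound 4 (0.02 log units; within the scatter) and a 1.5-fold lower number from compound 2 to compound 4 (0.17 log units; within the scatter) stay within the scatter, so a group with no ring has not been told apart from either ring at this position. Among the compounds shown here, the propanoylamino side chain is shared by compound 1 and compound 4, and the step between them is a 2.6-fold higher number from compound 1 to compound 4 (0.41 log units; beyond the scatter) with 5-aminopyridin-3-yl in place of 6-aminopyridin-3-yl on a saturated ring carbon; the low number of compound 1 therefore cannot be credited to the propanoyl group, and the only step here that leaves the scatter is this change at the other end of the molecule. Nothing measured here accounts for either the flat response at the carbonyl carbon or the difference between the two aminopyridinyl groups.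

Going by these compounds, whether an amine, a carboxylic acid or a chain longer than ethyl on this carbonyl carbon would also stay within the scatter remains open. On these data alone, it is also open whether 6-aminopyridin-3-yl would give a similar step when oxan-4-yl or pyrimidin-2-yl sits on the carbonyl carbon.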